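Chloro to methyl on the anilino ring of the shared core

The source may hold more compounds than are shown below. What is called first, only, known or untested is meant among the compounds shown, and "the series" means these compounds.

Measured compounds:
compound 1 `N#Cc1c(Nc2cccc(C(F)(F)F)c2)nc(SCc2cn(Cc3ccccc3Cl)nn2)nc1-c1ccccc1`: 3710 nM
compound 2 `N#Cc1c(Nc2cccc(Cl)c2)nc(SCc2cn(Cc3ccccc3Cl)nn2)nc1-c1ccccc1`: 3590 nM

In a functional assay on B16-F10 cells (Mus musculus) for inhibition, read by MTT assay, with a stated time of 72 h (a lower number here means a stronger inhibitor, a higher number a weaker inhibitor), compound 1 gives 3710 nM and compound 2 gives 3590 nM. Compound 2 holds the lower of the two numbers, but the gap between them is a 1.0-fold lower number from compound 1 to compound 2 (0.01 log units; within the scatter), which lies within the scatter, so the two compounds cannot be told apart on these data.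

The unmeasured compound 3 `Cc1cccc(Nc2nc(SCc3cn(Cc4ccccc4Cl)nn3)nc(-c3ccccc3)c2C#N)c1` differs from compound 2 by methyl in place of chloro on an aromatic carbon. For the measured compounds named here, the only measured step that touches this position is the one from trifluoromethyl to chloro, and it moved the number by a 1.0-fold lower number from compound 1 to compound 2 (0.01 log units; within the scatter), nothing beyond the scatter. Going by the values given here, the exchange of chloro for methyl at the same position has no measured precedent of its own; with the one comparable step flat, no movement beyond the scatter is expected in this assay in either direction.

Compound 3 is therefore estimated at 3600 nM, with a range from 1800 nM to 7200 nM. The estimate means a 1.0-fold higher number from compound 2 to compound 3 (0.00 log units; within the scatter), a step expected to stay within the scatter.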

Compound 3, half-maximal inhibitory concentration: 13500 nM
For compound 3 the middle estimate is 3.8-fold (0.57 log units) below the measured one; measured number above the stated range.
By their numbers in this assay, from the lowest: compounds 2 and 1 (each within the scatter of the next); then compound 3.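

In this assay the aromatic carbon that carries chloro in compound 2 proves sensitive to the group placed on it: methyl in place of chloro gives a 3.8-fold higher number from compound 2 to compound 3 (0.58 log units; beyond the scatter), and methyl in place of trifluoromethyl gives a 3.6-fold higher number from compound 1 to compound 3 (0.56 log units; beyond the scatter). The flat exchange between trifluoromethyl and chloro therefore does not extend to every group at this position; those two groups remain within the scatter of each other, while methyl alone stands apart, with the weaker number of the three. Nothing available here accounts for why methyl separates from the other two groups.

Three groups on one carbon leave open whether the weaker number belongs to methyl alone or also to other small groups, such as methoxy, fluoro or an amine at the same place. As far as these compounds go, it also remains open whether the 3-chlorophenyl to 3-methylphenyl step keeps its size when the 2-chlorobenzyl-type part of the shared core is replaced, for example by a group carrying a carboxylic acid.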